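A few compounds are considered here, and "the series" means these few. Any claim that something is new, unique, unknown or untested is made for them only; others in the source may bear on it.

Compounds measured in a functional assay on HT-29 cells (Homo sapiens) for inhibition, read by MTT assay, with a stated time of 48 h; on this read-out lower numbers stand for stronger inhibition and higher numbers for weaker inhibition:

compound 1, `COc1cc(/C=C/c2ccc(NC(=O)/C=C/c3ccc(C(F)(F)F)cc3)cc2)cc(OC)c1`, 1780 nM
compound 2, `COc1cc(/C=C/c2ccc(NC(=O)/C=C/c3ccc([N+](=O)[O-])cc3)cc2)cc(OC)c1`, 10700 nM
compound 3, `COc1cc(/C=C/c2ccc(OC(=O)/C=C/c3ccc(C(F)(F)F)cc3)cc2)cc(OC)c1`, 9090 nM

Compound 1 and compound 2 share one core and differ only by the change (nitro in place of trifluoromethyl on an aromatic carbon). That change made the step of a 6.0-fold higher number from compound 1 to compound 2 (0.78 log units; beyond the scatter).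

Compound 3 carries a different core; the difference between the core of compound 3 and the core of compound 1 is not broken down here. Its value in this assay lies close to that of compound 2, and its step to compound 1 is beyond the scatter.

Compound 4, `COc1cc(/C=C/c2ccc(OC(=O)/C=C/c3ccc([N+](=O)[O-])cc3)cc2)cc(OC)c1`, has not yet been measured in this assay. It relates to compound 3 through the change (nitro in place of trifluoromethyl on an aromatic carbon), the same change that separates compound 2 from compound 1, at the same place. Within the data shown here, on the single earlier example it is expected to move compound 4 by a 3.9-fold higher number from compound 3 to compound 4 (0.59 log units; beyond the scatter) in this assay, weakening inhibition because the matching step a 6.0-fold higher number from compound 1 to compound 2 (0.78 log units; beyond the scatter) went the same way; the expectation rests on one pair only, so the range is kept wide. Compound 4 is therefore estimated at 35000 nM, between 12000 nM and 100000 nM.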

Compound 4, half-maximal inhibitory concentration: > 20000 nM
Compound 4 gave a limit, no number; the forecaster's own chance of this, stated with the estimate: 25%; the middle value is on the limit's open side.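

In this assay, compound 4 gave only a limit and not a number, > 20000 nM. On the core of compound 3, putting nitro in place of trifluoromethyl produced an at least 2.2-fold higher number from compound 3 to compound 4 (0.34 log units; beyond the scatter), which runs in the same direction as the step on the core of compound 1, a 6.0-fold higher number from compound 1 to compound 2 (0.78 log units; beyond the scatter). The direction of the change therefore held on both cores in this pair of examples, but the size of the step on the second core remains unknown, and two pairs cannot establish a rule for the wider series: the same change on two cores in this assay, a 6.0-fold higher number (0.78 log units; beyond the scatter) from compound 1 to compound 2 and an at least 2.2-fold higher number (0.34 log units; beyond the scatter) from compound 3 to compound 4; the limit leaves it open whether they differ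

The compounds shown compare only trifluoromethyl and nitro on the aromatic ring, leaving open how a nitrile, an amine or a carboxylic acid at the same place would behave on either core. Also open, on these data alone, is whether the step would keep its direction on a core other than these two.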